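Sulfur oxidation state at the ring carbon: sulfoxide to sulfone

The source may report more compounds than this note shows. Statements on the series, on what has been measured and on what is new or still open speak of the compounds shown alone.

Compound 2 `CCCCCCC[S+]([O-])c1cc(-c2ccccc2)c(-c2ccccc2)nn1` carries the higher of the two numbers recorded so far in an assay on microsomes from liver for inhibition of sterol O-acyltransferase 1 (Rattus norvegicus) (a higher number here means a weaker inhibitor, a lower number a stronger inhibitor), where compound 2 gives 77000 nM. Its nearest neighbour is compound 1 `CCCCCCSc1cc(-c2ccccc2)c(-c2ccccc2)nn1`, which in this assay gives 62000 nM; the step of a 1.2-fold higher number from compound 1 to compound 2 (0.09 log units; within the scatter) lies within the scatter, so the two are not told apart.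

Compound 3 `CCCCCCS(=O)(=O)c1cc(-c2ccccc2)c(-c2ccccc2)nn1` differs from compound 2 by a group of 9 heavy atoms (6 carbon, 2 oxygen, 1 sulfur; no ring) in place of a group of 9 heavy atoms (7 carbon, 1 oxygen, 1 sulfur; no ring), on an aromatic carbon. Going by the values given here, the only measured step that bears on the sulfur-bearing chain at this position is a 1.2-fold higher number from compound 1 to compound 2 (0.09 log units; within the scatter), which was within the scatter. On that basis no step beyond the scatter is expected from compound 2 to compound 3 in this assay, and the estimated step is a 1.0-fold higher number from compound 2 to compound 3 (0.02 log units; within the scatter). For compound 3 the expected value in this assay is 80000 nM, with a range from 30000 nM to 200000 nM.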

Compound 3, half-maximal inhibitory concentration: 60000 nM
Compound 3: middle estimate off by 1.3-fold (0.12 log units), on the high side, and the stated range covers the measured number.
By their numbers in this assay, from the lowest: compounds 3, 1 and 2 (each within the scatter of the next).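

In this assay, going by these compounds alone, hexylsulfonyl in place of hexylsulfanyl on the same hexyl chain gives a 1.0-fold lower number from compound 1 to compound 3 (0.01 log units; within the scatter) and is the first step at this position in which only the sulfur changes. The other new step, with hexylsulfonyl in place of the group of 7 carbon, 1 oxygen and 1 sulfur, is a 1.3-fold lower number from compound 2 to compound 3 (0.11 log units; within the scatter) and so does not tell these two apart, which leaves all three sulfur-linked groups on this aromatic carbon indistinguishable in this assay. Nothing at hand explains why these numbers fall together.

Still open, on these data alone, is whether the sulfur link matters at all, which a hexyloxy group or an amine in its place would test. As far as these compounds go, it is also open whether a carboxylic acid at the chain end, a much longer chain or a change on either phenyl group moves the number beyond the scatter.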